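The source may report more compounds than this note shows. Statements on the series, on what has been measured and on what is new or still open speak of the compounds shown alone.

In an ADME assay on SH-SY5Y cells (Homo sapiens) for cytotoxicity, read by MTT assay, with a stated time of 72 h (on this read-out higher numbers stand for lower toxicity in this test and lower numbers for higher toxicity in this test), compound 1 (`CN(C)Cc1ccccc1Nc1cc(CNCCN2CCCCC2)cc(CNCCN2CCCCC2)c1`) gives > 100000 nM, which is a limit of the assay. Compound 2 (`c1ccc(-c2cc(CNCCN3CCCCC3)cc(CNCCN3CCCCC3)c2)c(CN2CCCCC2)c1`) gives > 100000 nM, again a limit. Compound 3 (`CN1CCN(Cc2ccccc2-c2cc(CNCCN3CCCCC3)cc(CNCCN3CCCCC3)c2)CC1`) gives > 100000 nM, so it too stands only at a limit and not at a number. All three thus sit at the limit of > 100000 nM in this assay, at which 3 of the 3 values shown sit. Compound 4 (`CN(C)Cc1ccccc1-c1cc(CNCCN2CCCCC2)cc(CNCCN2CCCCC2)c1`) differs from compound 3 at one place: dimethylamino in place of 4-methylpiperazin-1-yl on a saturated chain carbon bound to an aromatic carbon. Among the measured compounds shown here, the only measured step at that place is a step that the two limits leave unreadable from compound 2 to compound 3, and it offers no size to carry over. Nothing beyond the scatter is therefore expected in this assay, and the expected step is a number no higher from compound 3 to compound 4 (the limit leaves the size open). For compound 4 the estimated value is 100000 nM, with an expected range from 40000 nM to 200000 nM, most probably reported only as a limit.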

Compound 4, half-maximal cytotoxic concentration: > 100000 nM
Compound 4 gave a limit, no number (the forecaster's own chance of this, stated with the estimate: 85%); the middle value sits exactly at the limit.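

Among the compounds shown here, compound 4 stands only at a limit, as do compound 1, compound 2 and compound 3, and no step among the four can be read. The compounds shown leave open whether any of these changes alters cytotoxicity at all.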